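Chromone dithiocarbamates: methyl on the benzo ring of compound 3

The source may report more compounds than this note shows. Statements on the series, on what has been measured and on what is new or still open speak of the compounds shown alone.

Compound 3 `O=c1c(CSC(=S)N2CCOCC2)coc2ccccc12` gives 4000 nM in a functional assay on MCF7 cells (Homo sapiens) for antiproliferative activity, read by MTT assay, with a stated time of 72 h (a lower number here means a stronger inhibitor, a higher number a weaker inhibitor), the lowest of the three numbers in hand. Compound 2 `Cc1ccc2c(=O)c(CSC(=S)N(C(C)C)C(C)C)coc2c1` gives 6600 nM, which lies within the scatter of compound 3. Going by the values given here, compound 1 `O=c1c(CSC(=S)N2CCOCC2)coc2cc(Cl)ccc12` gives 8100 nM, and the only single-point step in the set is a 2.0-fold lower number from compound 1 to compound 3 (0.31 log units; beyond the scatter).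

Compound 4 `Cc1ccc2c(=O)c(CSC(=S)N3CCOCC3)coc2c1` differs from compound 3 by methyl in place of hydrogen on an aromatic carbon. Among the compounds with values here, no measured step covers this change: compound 2 carries the same methyl but also a different amine on the dithiocarbamate, so its number against compound 3 says only that the two values sit within the scatter of each other. Within the data shown here, the one step that does exist, the loss of a chloro from compound 1 to compound 3, was modest and went toward a lower number, and a small aromatic substituent on compound 3 is therefore not expected to bring a large step in either direction in this assay.

For compound 4 the expectation is a 1.3-fold higher number from compound 3 to compound 4 (0.10 log units; within the scatter), a change not expected to exceed the scatter. Compound 4 is estimated at 5000 nM, with a range from 2500 nM to 10000 nM.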

Compound 4, half-maximal inhibitory concentration: 20700 nM
The estimate for compound 4 lay 4.1-fold (0.62 log units) below the measured number, and the stated range ends below it.
By their numbers in this assay, from the lowest: compounds 3, 2 and 1 (each within the scatter of the next, the first and the last beyond it); then compound 4.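

In this assay, methyl in place of hydrogen on this aromatic carbon, meta to a fused ring and para to a fused ring, gives a 5.2-fold higher number from compound 3 to compound 4 (0.71 log units; beyond the scatter), so a single added carbon here is not a neutral change on the morpholin-4-yl series. Methyl in place of chloro on the same carbon gives a 2.6-fold higher number from compound 1 to compound 4 (0.41 log units; beyond the scatter), and with a 2.0-fold lower number from compound 1 to compound 3 (0.31 log units; beyond the scatter) this places hydrogen at the lowest number of the three substituents, chloro next and methyl highest, so neither substituent shown improves on hydrogen. With the methyl held fixed, the dithiocarbamate amine also matters, since morpholin-4-yl in place of diisopropylamino gives a 3.1-fold higher number from compound 2 to compound 4 (0.50 log units; beyond the scatter), a step that the comparison of compound 2 with compound 3 alone could not show.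

The compounds shown give no measured basis for explaining any of these steps. Open questions are how fluoro, methoxy or a longer chain such as ethyl would behave on this carbon, and whether diisopropylamino on the core without the methyl would follow the same step as on the methyl-bearing core.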